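The compounds below may be only part of what the source reports. "The series", "measured", "known", "first", "only" and "open" are said of these compounds alone.

Measured in a functional assay on HL-60 cells (Homo sapiens) for inhibition, read by CCK-8 assay, with a stated time of 48 h, tested at 20 uM; a higher number here means more inhibition of growth at the concentration tested, a lower number less inhibition of growth:
- compound 1 `N#C/C(=C\c1ccccc1OS(=O)(=O)c1ccc(Cl)cc1)C(=O)Nc1nnc(Cc2ccc(F)cc2)s1` gives 20%
- compound 2 `N#C/C(=C\c1ccccc1OS(=O)(=O)c1ccc(Cl)cc1)C(=O)Nc1nnc(-c2cccc(F)c2)s1` gives 42%
- compound 3 `N#C/C(=C\c1ccccc1OS(=O)(=O)c1ccc(F)cc1)C(=O)Nc1nnc(Cc2cccc(F)c2)s1` gives 22%

Compound 2 stands highest of the three, and its gaps to compound 1 and compound 3 both lie beyond the scatter. Next is compound 4 `N#C/C(=C\c1ccccc1OS(=O)(=O)c1ccc(Cl)cc1)C(=O)Nc1nnc(Cc2ccc(Cl)cc2)s1` which is still unmeasured. The change from compound 2 4-chlorobenzyl in place of 3-fluorophenyl on an aromatic carbon amounts to 4-chlorobenzyl in place of 3-fluorophenyl on an aromatic carbon.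

For the measured compounds named here, one measured step bears on this directly. The modest step of a number 22 percentage points higher from compound 1 to compound 2 (beyond the scatter) came with 3-fluorophenyl in place of 4-fluorobenzyl, and the present change runs the opposite way. Going by the values given here, compound 4 shares everything with compound 1 at 20% except 4-chlorobenzyl in place of 4-fluorobenzyl, and no measured pair isolates that swap. A fall of similar size, beyond the scatter, is therefore expected, and the estimated move is a number 18 percentage points lower from compound 2 to compound 4 (beyond the scatter) on this reasoning. In this assay the estimated value for compound 4 is 24% with an expected range from 12% to 38% around it.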

Compound 4, percent growth inhibition at one concentration: 15%
Beside the measured number, compound 4's estimate is 9 percentage points above it; the range from low to high includes it.
By their numbers in this assay, from the lowest: compounds 4, 1 and 3 (each within the scatter of the next); then compound 2.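

In this assay, for the compounds shown here, the step of a number 5 percentage points lower from compound 1 to compound 4 (within the scatter) gives the first direct look at the halogen on the benzyl group, and it does not separate chloro from fluoro. The step of a number 27 percentage points lower from compound 2 to compound 4 (beyond the scatter) adds a second pair to the earlier a number 22 percentage points higher from compound 1 to compound 2 (beyond the scatter) and runs the opposite way. At this position, then, 3-fluorophenyl stands beyond the scatter above both 4-halobenzyl groups, a contrast resting on compound 1 and compound 4 alone. Nothing available gives a cause for these steps.

Still open, going by these compounds, is whether the gap follows the methylene link or the place of the halogen, a question that 4-fluorophenyl or 3-chlorophenyl on the core of compound 2 could address. Also open, on these data alone, is how an aminophenyl or carboxyphenyl group would fare at this position.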